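Swapping Chloro for Nitro at the Assay Limit

A few compounds are considered here, and "the series" means these few. Any claim that something is new, unique, unknown or untested is made for them only; others in the source may bear on it.

Three compounds sharing one core were tested in a functional assay on DU-145 cells (Homo sapiens) for cytotoxicity, read by MTT assay, with a stated time of 48 h; on this read-out lower numbers stand for stronger inhibition and higher numbers for weaker inhibition. Compound 2 `Cn1c(/C=C2/C(=O)Nc3ccc(Cl)cc32)nc2ccccc21` carries a chloro group, and in this assay compound 2 gives 38900 nM. Compound 1 `Cn1c(/C=C2/C(=O)Nc3ccc([N+](=O)[O-])cc32)nc2ccccc21` differs from compound 2 by nitro in place of chloro on an aromatic carbon. In this assay compound 1 reaches only a limit, > 50000 nM. The step recorded is an at least 1.2-fold higher number from compound 2 to compound 1 (0.10 log units; that floor lies within the scatter). Compound 3 `CCn1c(/C=C2/C(=O)Nc3ccc(Cl)cc32)nc2ccccc21` differs from compound 2 by methyl in place of hydrogen on a saturated chain carbon bound to an aromatic nitrogen. In this assay compound 3 also reaches only a limit, > 50000 nM. The step recorded is an at least 1.2-fold higher number from compound 2 to compound 3 (0.10 log units; that floor lies within the scatter). Both of those values sit at the limit of > 50000 nM in this assay, at which 2 of the 3 values shown sit, so neither step has a measured size beyond its floor.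

Compound 4 `CCn1c(/C=C2/C(=O)Nc3ccc([N+](=O)[O-])cc32)nc2ccccc21` has not yet been measured. It differs from compound 3 by nitro in place of chloro on an aromatic carbon. This is the same change as that from compound 2 to compound 1, placed on a core that already carries the ethyl group of compound 3 rather than the methyl group of compound 2. Since the earlier step was an at least 1.2-fold higher number from compound 2 to compound 1 (0.10 log units; that floor lies within the scatter), and compound 3 stands at a limit of > 50000 nM, compound 4 is expected to remain at a limit, with an estimated step that the limit leaves unreadable from compound 3 to compound 4. The estimate for compound 4 is 90000 nM, expected to fall between 50000 nM and 250000 nM, with the most likely outcome being that only a limit is reported.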

Compound 4, half-maximal inhibitory concentration: > 50000 nM
Compound 4: only a limit was reported; the forecaster's own chance of this, stated with the estimate: 85%; the middle value does not contradict the limit.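

In this assay, neither new step can be read, from compound 3 to compound 4 or from compound 1 to compound 4, because all three compounds stand at the same limit: the limit of > 50000 nM in this assay, at which 3 of the 4 values shown sit.

The compounds shown leave open what nitro in place of chloro does on the core of compound 3, and how far the activity of compound 1, compound 3 and compound 4 lies past that limit.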